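Two Chlorophenyl Positions on a Triazole-Linked Sulfonamide

The source may hold more compounds than are shown below. What is called first, only, known or untested is meant among the compounds shown, and "the series" means these compounds.

Measured in a functional assay on OVCAR-3 cells (Homo sapiens) for antiproliferative activity, read by MTT assay, with a stated time of 24 h (a higher number here means a weaker inhibitor, a lower number a stronger inhibitor), so far:
Compound 1 `O=c1[nH]cc(S(=O)(=O)Nc2ccccc2-c2cn(-c3ccccc3Cl)nn2)c(=O)[nH]1` gives 3170 nM.
Compound 2 `O=c1[nH]cc(S(=O)(=O)Nc2ccccc2-c2cn(-c3cccc(Cl)c3)nn2)c(=O)[nH]1` gives 2180 nM.
Compound 3 `O=c1[nH]cc(S(=O)(=O)Nc2cccc(-c3cn(-c4ccccc4Cl)nn3)c2)c(=O)[nH]1` gives 5370 nM.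

Compound 2 differs from compound 1 by 3-chlorophenyl in place of 2-chlorophenyl on an aromatic nitrogen, and that change made a 1.5-fold lower number from compound 1 to compound 2 (0.16 log units; within the scatter). Compound 3 has a different core from compound 1; the difference between the two cores is not broken down here. Compound 3 has the highest number of the three, and against compound 2 the gap is beyond the scatter, while against compound 1 it is within it.

Compound 4 `O=c1[nH]cc(S(=O)(=O)Nc2cccc(-c3cn(-c4cccc(Cl)c4)nn3)c2)c(=O)[nH]1` is not yet measured. It differs from compound 3 by 3-chlorophenyl in place of 2-chlorophenyl on an aromatic nitrogen, the same change as from compound 1 to compound 2, at the same place. Because a 1.5-fold lower number from compound 1 to compound 2 (0.16 log units; within the scatter) was within the scatter, a similarly small step is expected, a 1.5-fold lower number from compound 3 to compound 4 (0.17 log units; within the scatter), and compound 4 is estimated at 3600 nM, plausibly between 1800 nM and 7200 nM.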

Compound 4, half-maximal inhibitory concentration: 3410 nM
The estimate for compound 4 lay 1.1-fold (0.02 log units) above the measured number, within the range that was stated.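

In this assay, putting 3-chlorophenyl in place of 2-chlorophenyl gave a 1.6-fold lower number from compound 3 to compound 4 (0.20 log units; within the scatter). Set beside the same swap on the other core, the two steps agree: the same change on two cores in this assay, a 1.5-fold lower number (0.16 log units; within the scatter) from compound 1 to compound 2 and a 1.6-fold lower number (0.20 log units; within the scatter) from compound 3 to compound 4, 1.1-fold (0.03 log units) apart, within the scatter of two such steps. This shows that the small step carried over between these two cores, but each step lies within the scatter, so it does not show that the swap truly changes the number, and two cores cannot establish a rule for the wider series.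

The compounds shown leave open how a phenyl bearing a methoxy group or an amine instead of chlorine would read in this assay. Going by these compounds, whether the swap behaves the same way on any further core also remains open.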